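The compounds below may be only part of what the source reports. "The series", "measured", "known", "first", "only" and "open" are said of these compounds alone.

Compound 1 `CNc1cc(Oc2c(OC)cc3cc(C#N)ccc3c2OC)nc(Nc2ccc(C#N)cc2)n1` carries a methylamino group on the shared core; in an ADME assay on MT4 cells (Homo sapiens) for cytotoxicity, read by MTT assay, with a stated time of 5 days (on this read-out lower numbers stand for higher toxicity in this test and higher numbers for lower toxicity in this test), compound 1 gives 239000 nM. Compound 2 `CCCNc1cc(Oc2c(OC)cc3cc(C#N)ccc3c2OC)nc(Nc2ccc(C#N)cc2)n1` extends the same group to propylamino. Compound 2 returns only a limit in this assay, > 125000 nM, not a number. Compound 3 `COc1cc2cc(C#N)ccc2c(OC)c1Oc1cc(NCC(C)C)nc(Nc2ccc(C#N)cc2)n1` bears an isobutylamino group. Compound 3 likewise returns only a limit, > 125000 nM. Compound 2 therefore stands at a limit, and one of the two other values shown is a limit as well; only compound 1 carries a number. The steps a step that the limit leaves unreadable from compound 1 to compound 2 and a step that the limit leaves unreadable from compound 1 to compound 3 cannot be sized because of the limit of > 125000 nM in this assay, at which 2 of the 3 values shown sit. The step that the two limits leave unreadable from compound 2 to compound 3 is equally unreadable.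

Compound 4 `CCC(CC)Nc1cc(Oc2c(OC)cc3cc(C#N)ccc3c2OC)nc(Nc2ccc(C#N)cc2)n1` differs from compound 2 by ethyl in place of hydrogen on a saturated chain carbon bound to a nitrogen on an aromatic ring and a saturated chain carbon. For the measured compounds named here, the one earlier step that adds carbon at this saturated chain carbon, a step that the two limits leave unreadable from compound 2 to compound 3, gives no readable size, and no step from a numbered value reaches compound 4. No direction beyond the scatter can be inferred; the expectation is that compound 4 stays near the limit of this assay. Compound 4 is therefore expected at 150000 nM, with a range of 60000 nM to 400000 nM. The step this implies is estimated as a step that the limit leaves unreadable from compound 2 to compound 4.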

Compound 4, half-maximal cytotoxic concentration: > 125000 nM
Compound 4 was reported as a limit (the forecaster's own chance of this, stated with the estimate: 65%); the middle value is on the limit's open side.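

Compound 4 returns only a limit in this assay (> 125000 nM). The steps linking compound 1, compound 2 and compound 3 to compound 4 therefore cannot be read: the limit of > 125000 nM in this assay, at which 3 of the 4 values shown sit. Left open is how far the toxicity in this test of compound 2, compound 3 and compound 4 differs from that of compound 1 (239000 nM).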